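Shifting the chromone attachment in compound 4

A few compounds are considered here, and "the series" means these few. Any claim that something is new, unique, unknown or untested is made for them only; others in the source may bear on it.

Measured so far:
compound 1 `Cc1nnc(SCc2coc3ccc(Cl)cc3c2=O)o1`: 3500 nM
compound 2 `Cc1cc(C)n2nc(SCc3nnc(SCc4coc5ccccc5c4=O)n3N)nc2n1`: 3600 nM
compound 3 `Cc1cc(C)n2nc(SCc3nnc(SCc4coc5ccccc5c4=O)n3-c3ccccc3)nc2n1`: 12400 nM

In a functional assay on SW480 cells (Homo sapiens) for cytotoxicity, read by MTT assay, with a stated time of 72 h (on this read-out lower numbers stand for stronger inhibition and higher numbers for weaker inhibition), compound 3 gives 12400 nM, the highest of the three numbers. Its nearest neighbour is compound 2, at 3600 nM, and the furthest is compound 1, at 3500 nM; both sit beyond the scatter below compound 3. Among the compounds with values here, the one step between neighbours, a 3.4-fold higher number from compound 2 to compound 3 (0.54 log units; beyond the scatter), concerns the phenyl in place of amino on an aromatic nitrogen and has no bearing on the change now considered.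

Compound 4 `Cc1cc(C)n2nc(SCc3nnc(SCc4cc(=O)c5ccccc5o4)n3-c3ccccc3)nc2n1` differs from compound 3 only by a group of 11 heavy atoms (9 carbon, 2 oxygen; one six-membered aromatic ring of carbon only, one six-membered aromatic ring with 1 hetero atom) in place of a group of 11 heavy atoms (9 carbon, 2 oxygen; one six-membered aromatic ring of carbon only, one six-membered aromatic ring with 1 hetero atom), on a saturated chain carbon bound to a sulfur; the two have the same atoms, joined differently. Within the data shown here, no measured pair tells how this assay answers such a rearrangement, so the expectation rests on compound 3 alone, with a wide range around it. Compound 4 is therefore expected to show no step beyond the scatter, a 1.0-fold lower number from compound 3 to compound 4 (0.01 log units; within the scatter), in this assay. Compound 4 is estimated at 12000 nM, within 4000 nM to 40000 nM.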

Compound 4, half-maximal inhibitory concentration: > 25000 nM
Compound 4: no number, only a limit; the forecaster's own chance of this, stated with the estimate: 10%; at least 2.0-fold (0.31 log units) between middle value and limit.
By their numbers in this assay, from the lowest: compounds 1 and 2 (each within the scatter of the next); then compound 3. At a limit, above all of these: compound 4.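

Compound 4 gives only a limit in this assay, not a number: the limit of > 25000 nM in this assay, at which 1 of the 4 values shown sits. The earlier compounds varied other parts of the structure, and this is the first change among those shown that keeps the atoms the same and alters only how the group on a saturated chain carbon bound to a sulfur is joined. The result is an at least 2.0-fold higher number from compound 3 to compound 4 (0.30 log units; that floor lies within the scatter), so the rearrangement gives no sign of a lower number, but the floor of this step does not establish a change beyond the scatter.

From the compounds shown here alone, the size of the step cannot be read beyond that floor, and whether the same rearrangement would give a number with amino in place of phenyl on the aromatic nitrogen stays open. Also open, going by these compounds, is how a longer chain at this place, or a carboxylic acid on the entering group, would read in this assay.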